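Chlorophenyl Exchange Under an Unreadable Ceiling

The source may hold more compounds than are shown below. What is called first, only, known or untested is meant among the compounds shown, and "the series" means these compounds.

Compound 3 `CN1CCN(c2nc(-c3cccc(O)c3)nc3[nH]cnc23)CC1` carries a 3-hydroxyphenyl on the shared core. In an assay on cells for displacement of a labelled ligand from adenosine receptor A3 (Homo sapiens), read by scintillation counting and radioligand binding, with a stated time of 180 min, tested at 10 uM (a higher number here means more inhibition at the concentration tested (going by the name of the read-out), a lower number less inhibition), compound 3 gives > 80%, which is a limit of the assay and not a number. Compound 2 `CN1CCN(c2nc(-c3cc(Cl)ccc3Cl)nc3[nH]cnc23)CC1` shows the same picture, since in this assay compound 2 gives > 80%, again a limit. The step that the two limits leave unreadable from compound 2 to compound 3 is therefore unreadable. Compound 1 `Clc1ccc(-c2nc(N3CCCCC3)c3nc[nH]c3n2)cc1` also reaches a limit, as in this assay compound 1 gives > 80%. All three compounds sit at the limit of > 80% in this assay, at which 3 of the 3 values shown sit.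

The change leading to compound 4 `CN1CCN(c2nc(-c3ccc(Cl)cc3)nc3[nH]cnc23)CC1` is 4-chlorophenyl in place of 3-hydroxyphenyl on an aromatic carbon. Going by the values given here, the only measured step does not bear readably on this exchange, because both of its ends rest at the limit of > 80% in this assay, at which 3 of the 3 values shown sit. Since compound 1, which also bears a 4-chlorophenyl, gives > 80%, compound 4 is expected to sit at the same limit, and the step that the limit leaves unreadable from compound 3 to compound 4 is expected to show no readable change. The estimate for compound 4 in this assay is 90%, ranging from 78% to 99%.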

Compound 4, a percentage reported as inhibition, at one concentration (the size of the read-out at that concentration, not a potency): > 80%
Compound 4: only a limit was reported; the forecaster's own chance of this, stated with the estimate: 85%; the middle value is on the limit's open side.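

No step from compound 4 to compound 1, compound 2 or compound 3 can be read, since all four compounds rest at one limit of the assay: the limit of > 80% in this assay, at which 4 of the 4 values shown sit.

The compounds shown leave open how the 4-chlorophenyl, 3-hydroxyphenyl and 2,5-dichlorophenyl groups, or the 4-methylpiperazin-1-yl and piperidin-1-yl groups, compare in this assay.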